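The source may hold more compounds than are shown below. What is called first, only, known or untested is meant among the compounds shown, and "the series" means these compounds.

Compound 1, `COc1cccc(C(=O)/C=C/c2ccccc2)c1`, gives 14700 nM in an ADME assay on HT-29 cells (Homo sapiens) for inhibition, read by trypan blue exclusion, with a stated time of 72 h; on this read-out higher numbers stand for weaker inhibition of growth and lower numbers for stronger inhibition of growth. Compound 2, `O=C(/C=C/c1ccccc1)c1cccc(C(F)(F)F)c1`, gives > 20000 nM in this assay, which is a limit of the assay and not a number (the limit of > 20000 nM in this assay, at which 1 of the 3 values shown sits). Compound 3, `O=C(/C=C/c1ccccc1)c1ccccc1C(F)(F)F`, gives 10800 nM in this assay.

Compound 3 holds the lowest of the two numbers, and compound 1 lies within the scatter of it, so no order between the two can be claimed. The difference between the cores of compound 2 and compound 3 is not broken down here. The measured step of an at least 1.3-fold lower number from compound 2 to compound 1 (0.13 log units; that floor lies within the scatter) comes from methoxy in place of trifluoromethyl on an aromatic carbon. Compound 4, `COc1ccccc1C(=O)/C=C/c1ccccc1`, is not yet measured; it arises from compound 3 by methoxy in place of trifluoromethyl on an aromatic carbon. This is the same kind of change, not the same change: in compound 2 the group sits meta to a large group, in compound 3 it sits ortho to a large group. For compound 4 the step of a 1.2-fold lower number from compound 3 to compound 4 (0.08 log units; within the scatter) is expected to be small, resting on the step of an at least 1.3-fold lower number from compound 2 to compound 1 (0.13 log units; that floor lies within the scatter) and on the number of compound 3, 10800 nM. Compound 4 is therefore estimated at 9000 nM, expected to fall between 3500 nM and 25000 nM.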

Compound 4, concentration for 50% growth inhibition: 14800 nM
Compound 4: middle estimate off by 1.6-fold (0.22 log units), on the low side; the range from low to high includes it.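

In this assay, methoxy in place of trifluoromethyl on an aromatic carbon, ortho to a large group, gives a 1.4-fold higher number from compound 3 to compound 4 (0.14 log units; within the scatter), so on the core of compound 3 the change moves the number by no more than repeated measurements would. Set beside the same change on the other core, the two steps read as follows: the same change on two cores in this assay, an at least 1.3-fold lower number (0.13 log units; that floor lies within the scatter) from compound 2 to compound 1 and a 1.4-fold higher number (0.14 log units; within the scatter) from compound 3 to compound 4; the limit leaves it open whether they differ. Compound 2 gives > 20000 nM, which is a limit of the assay and not a number, so the two steps show neither that the change carries over from one core to the other at the same size nor that it does not.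

The compounds shown carry only trifluoromethyl or methoxy, so they leave open how an amine, a carboxylic acid, a hydroxyl or a longer chain such as ethoxy would read on the same cores in this assay. They also leave open what any group would do on the second aromatic ring, which carries no group in any of the four compounds.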